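Chlorophenyl hydrazide series: positional change and expected potency

The source may report more compounds than this note shows. Statements on the series, on what has been measured and on what is new or still open speak of the compounds shown alone.

Two pairs of chlorophenyl hydrazides are compared in a functional assay on SGC-7901 cells (Homo sapiens) for antiproliferative activity, read by MTT assay, with a stated time of 24 h; a lower number here means a stronger inhibitor, a higher number a weaker inhibitor. Compound 1 `O=C(NNc1ccccc1Cl)c1ccc(NS(=O)(=O)c2cnc(O)nc2O)cc1` gives 3630 nM in this assay. Compound 2 `O=C(NNc1cccc(Cl)c1)c1ccc(NS(=O)(=O)c2cnc(O)nc2O)cc1` carries 3-chlorophenyl in place of 2-chlorophenyl on an amine nitrogen and gives 11600 nM in this assay, so that change produced a 3.2-fold higher number from compound 1 to compound 2 (0.50 log units; beyond the scatter). Compound 3 `O=C(NNc1ccccc1Cl)c1cccc(NS(=O)(=O)c2cnc(O)nc2O)c1` gives 2270 nM in this assay, the lowest of the three numbers, although its gap to compound 1 lies within the scatter; the difference between the cores of compound 1 and compound 3 is not broken down here. Compound 4 `O=C(NNc1cccc(Cl)c1)c1cccc(NS(=O)(=O)c2cnc(O)nc2O)c1` has not yet been measured. It differs from compound 3 by 3-chlorophenyl in place of 2-chlorophenyl on an amine nitrogen, the same change as between compound 1 and compound 2, made at the same kind of position. Among the measured compounds shown here, only one measured instance of this change exists, so the expectation for compound 4 is a 3.1-fold higher number from compound 3 to compound 4 (0.49 log units; beyond the scatter) in this assay, resting on a 3.2-fold higher number from compound 1 to compound 2 (0.50 log units; beyond the scatter) transferred onto the core of compound 3. Compound 4 is therefore expected to give about 7000 nM in this assay, most likely between 3500 nM and 15000 nM.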

Compound 4, half-maximal inhibitory concentration: 11800 nM
Beside the measured number, compound 4's estimate is 1.7-fold (0.23 log units) below it; measured number inside the range.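

On the core of compound 3, 3-chlorophenyl in place of 2-chlorophenyl on an amine nitrogen gives a 5.2-fold higher number from compound 3 to compound 4 (0.72 log units; beyond the scatter) in this assay, the same direction as on the core of compound 1. Within the scatter, the two steps agree in size, so the change carries from one core to the other in this pair of cores: the same change on two cores in this assay, a 3.2-fold higher number (0.50 log units; beyond the scatter) from compound 1 to compound 2 and a 5.2-fold higher number (0.72 log units; beyond the scatter) from compound 3 to compound 4, 1.6-fold (0.21 log units) apart, within the scatter of two such steps

Among the compounds shown here, this rests on only two pairs and a single read-out, so it does not show that the change would carry to any further core, and it does not show what lies behind the higher numbers of the 3-chlorophenyl compounds.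

The compounds shown leave open whether a phenyl without chlorine, or a phenyl carrying fluorine, methoxy or trifluoromethyl in place of chlorine, would give numbers like those of the chlorophenyl compounds on either core. They also leave open whether the step keeps its size on other cell lines or at other exposure times than in this assay.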